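Disulfide Thymidine Analogues: Varying the Chain on Sulfur

A few compounds are considered here, and "the series" means these few. Any claim that something is new, unique, unknown or untested is made for them only; others in the source may bear on it.

Measured so far:
compound 1 `Cc1cn([C@H]2C[C@H](SSc3ccccc3[N+](=O)[O-])[C@@H](CO)O2)c(=O)[nH]c1=O`: 31000 nM
compound 2 `C=CCSS[C@H]1C[C@H](n2cc(C)c(=O)[nH]c2=O)O[C@@H]1CO`: 34000 nM

In a functional assay on MOLT-4 cells (Homo sapiens) for cytotoxicity (a higher number here means a weaker inhibitor, a lower number a stronger inhibitor), compound 1 gives 31000 nM and compound 2 gives 34000 nM. Going by the values given here, the single step between them, a 1.1-fold higher number from compound 1 to compound 2 (0.04 log units; within the scatter), exchanges a 2-nitrophenyl for an allyl on the outer sulfur, and the two numbers stand within the scatter of each other; compound 2 is therefore not distinguishable from compound 1 on the numbers at hand.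

Compound 3 `CCCCSS[C@H]1C[C@H](n2cc(C)c(=O)[nH]c2=O)O[C@@H]1CO` follows from compound 2 by propyl in place of vinyl on a saturated chain carbon bound to a sulfur. Among the compounds with values here, the only step that bears on this change is a 1.1-fold higher number from compound 1 to compound 2 (0.04 log units; within the scatter), which shows that a large exchange of the group on the outer sulfur left this assay unmoved. A smaller change at the same chain is expected to do no more, so compound 3 is estimated at 34000 nM (range 15000 nM to 75000 nM), a step of no change at the digits printed from compound 2 to compound 3 (within the scatter) that is expected to stay within the scatter.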

Compound 3, half-maximal inhibitory concentration: 28000 nM
The estimate for compound 3 lay 1.2-fold (0.08 log units) above the measured number; the measured number falls inside the stated range.
By their numbers in this assay, from the lowest: compounds 3, 1 and 2 (each within the scatter of the next).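

Putting propyl in place of vinyl on a saturated chain carbon bound to a sulfur removes the one double bond of the chain and gives a 1.2-fold lower number from compound 2 to compound 3 (0.08 log units; within the scatter), so in this assay that double bond is not needed for a number of this size. Exchanging the aromatic group on the outer sulfur for a saturated chain gives a 1.1-fold lower number from compound 1 to compound 3 (0.04 log units; within the scatter), which places a fully saturated chain level with the aromatic group as well as with allyl. Nothing measured here accounts for this flatness across the three groups on the outer sulfur.

The compounds shown leave open whether a longer chain than butyl, or a chain ending in an amine or a carboxylic acid, would carry the number in this assay beyond the scatter. They also leave open whether the disulfide itself matters, since all three compounds share it.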